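Varying the amine on a shared core

The source may report more compounds than this note shows. Statements on the series, on what has been measured and on what is new or still open speak of the compounds shown alone.

Of the compounds shown here, three built on one shared core have been tested in a functional assay on L02 cells (Homo sapiens) for inhibition, read by Griess assay, with stated times of 1 h and 24 h (on this read-out lower numbers stand for stronger inhibition and higher numbers for weaker inhibition), so far. Compound 1 `COc1cc(/C=C/c2nc(NC3CC3)c3sccc3n2)cc(OC)c1OC` carries a cyclopropylamino group, and in this assay compound 1 gives only a limit of > 1000000 nM rather than a number. Compound 2 `CCN1CCN(c2nc(/C=C/c3cc(OC)c(OC)c(OC)c3)nc3ccsc23)CC1` carries a 4-ethylpiperazin-1-yl group in the same place, and in this assay compound 2 likewise gives only a limit of > 1000000 nM and no number. Among the measured compounds shown here, compound 3 `COc1cc(/C=C/c2nc(N(C)c3ccccc3)c3sccc3n2)cc(OC)c1OC` carries a methyl(phenyl)amino group and is the one compound with a reported number: in this assay compound 3 gives 767000 nM as its half-maximal inhibitory concentration. The move an at least 1.3-fold lower number from compound 1 to compound 3 (0.11 log units; that floor lies within the scatter) and the move an at least 1.3-fold lower number from compound 2 to compound 3 (0.11 log units; that floor lies within the scatter) are floors only, and each floor lies within the scatter, so the three compounds cannot be ordered against each other. Two of the three values sit at the limit of > 1000000 nM in this assay, at which 2 of the 3 values shown sit, and so tell nothing about size.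

Compound 4 `COc1cc(/C=C/c2nc(NCc3ccncc3)c3sccc3n2)cc(OC)c1OC` is not yet measured. It differs from compound 3 in one place: ((pyridin-4-yl)methyl)amino in place of methyl(phenyl)amino on an aromatic carbon. For the measured compounds named here, the two measured steps at this position, ending at compound 3, are the only guide, and neither can be read beyond the scatter. No step beyond the scatter is therefore expected in this assay in either direction. Compound 4 is expected to give about 800000 nM, between 300000 nM and 2000000 nM, with a fair chance that only a limit is reported. The expected step is thus a 1.0-fold higher number from compound 3 to compound 4 (0.02 log units; within the scatter).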

Compound 4, half-maximal inhibitory concentration: 374000 nM
Beside the measured number, compound 4's estimate is 2.1-fold (0.33 log units) above it; measured number inside the range.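

In this assay, among the compounds shown here, this position now gives a step beyond the scatter for the first time: a 2.1-fold lower number from compound 3 to compound 4 (0.31 log units; beyond the scatter). Going by these compounds, the two compounds that stop at a limit can now also be compared with a real number, and the floors an at least 2.6-fold lower number from compound 2 to compound 4 (0.42 log units; beyond the scatter) and an at least 2.6-fold lower number from compound 1 to compound 4 (0.42 log units; beyond the scatter) both clear the scatter, although the true size of each remains unknown. Compound 4 is therefore the one compound shown whose steps to all the others lie beyond the scatter, and the change that sets it apart from compound 3 brings in a hydrogen-bond donor and a hetero atom in the six-membered aromatic ring together.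

Which of those two differences matters remains open, and a benzylamino group at this position, keeping the donor with a ring of carbon only, would separate them in this assay. The step between compound 1 and compound 2 cannot be read, and the two cannot be ordered against each other, because each gives only a limit: the limit of > 1000000 nM in this assay, at which 2 of the 4 values shown sit.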